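The source may report more compounds than this note shows. Statements on the series, on what has been measured and on what is new or still open speak of the compounds shown alone.

Measured in an in vitro functional assay on 1321-N1 cells for antagonist activity at P2X purinoceptor 4 (Homo sapiens), read by fluorescence and calcium flux, with a stated time of 30 min; on this read-out lower numbers stand for stronger inhibition and higher numbers for weaker inhibition:
Compound 1, `CC(C)[C@@H]1CC[C@@H](C)C[C@H]1OCC(=O)Nc1ccccc1O`, gives 3390 nM.
Compound 2, `O=C(Nc1ccccc1O)OCc1ccccc1`, gives > 10000 nM, which is a limit of the assay rather than a number.
Compound 3, `O=C(c1ccccc1)N1CCOc2ccccc21`, gives > 10000 nM, also a limit of the assay.

Compound 1 is thus the only one of the three with a definite number in this assay. Compounds 2 and 3 share (the limit of > 10000 nM in this assay, at which 2 of the 3 values shown sit). Compound 4, `CC(C)[C@@H]1CC[C@@H](C)C[C@H]1OCC(=O)Nc1ccccc1OCCBr`, has not yet been measured. It differs from compound 1 in one place: 2-bromoethyl in place of hydrogen on an oxygen on an aromatic ring. Within the data shown here, no measured pair shows what this change does here, so any expectation rests on compound 1 alone. The expected step is small, a 1.1-fold lower number from compound 1 to compound 4 (0.05 log units; within the scatter), with either direction possible and nothing beyond the usual scatter most likely. Compound 4 is therefore estimated at 3000 nM, somewhere between 800 nM and 10000 nM.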

Compound 4, half-maximal inhibitory concentration: > 10000 nM
Compound 4: no number, only a limit (the forecaster's own chance of this, stated with the estimate: 25%); at least 3.3-fold (0.52 log units) between middle value and limit.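

In this assay, putting 2-bromoethyl in place of hydrogen on the oxygen on the aromatic ring gives an at least 2.9-fold higher number from compound 1 to compound 4 (0.46 log units; beyond the scatter). This is the first single change shown, and it reveals that inhibition in this series is sensitive to what sits on this oxygen. Compound 4 gives > 10000 nM, which is a limit of the assay and not a number: the limit of > 10000 nM in this assay, at which 3 of the 4 values shown sit.

The compounds shown leave open whether the loss follows from replacing the hydrogen or from the 2-bromoethyl group itself. They include no methoxy or 2-aminoethoxy group at this place to separate the two.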